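From 2-chlorophenyl to 4-chlorophenyl on a shared core

The source may hold more compounds than are shown below. What is called first, only, known or untested is meant among the compounds shown, and "the series" means these compounds.

Compound 1 `CNC(=O)c1cc(C(=O)N[C@H]2CC[C@H](O)CC2)c([C@@H](C)c2cccc(F)c2)o1` gives 73 nm/s
Compound 2 `CNC(=O)c1cc(C(=O)N[C@H]2CC[C@H](O)CC2)c([C@@H](C)c2ccccc2Cl)o1` gives 78 nm/s

In an ADME assay for permeability (on this read-out lower numbers stand for lower permeability and higher numbers for higher permeability), these two values lie within the scatter of each other, so compound 2 stands level with compound 1 on the numbers available. Compound 3 `CNC(=O)c1cc(C(=O)N[C@H]2CC[C@H](O)CC2)c([C@@H](C)c2ccc(Cl)cc2)o1` differs from compound 2 by a single exchange (4-chlorophenyl in place of 2-chlorophenyl on a saturated chain carbon bound to an aromatic carbon and a saturated chain carbon), with 4-chlorophenyl in place of 2-chlorophenyl on a saturated chain carbon bound to an aromatic carbon and a saturated chain carbon. Among the measured compounds shown here, one measured step bears on this place: a 1.1-fold higher number from compound 1 to compound 2 (0.03 log units; within the scatter) (2-chlorophenyl in place of 3-fluorophenyl). For the measured compounds named here, that step is a different exchange, and no measured compound carries 4-chlorophenyl, so the evidence is thin. It offers no direction, and no step beyond the scatter is expected in this assay for this exchange. The estimate means a 1.0-fold lower number from compound 2 to compound 3 (0.02 log units; within the scatter) as the expected step. For compound 3 the expected value is 75 nm/s within an estimated range of 40 nm/s to 140 nm/s on this read-out.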

Compound 3, apparent permeability: 150 nm/s
Compound 3: the middle estimate sits 2.0-fold (0.30 log units) below what was measured, and the stated range ends below it.
By their numbers in this assay, from the lowest: compounds 1, 2 and 3 (each within the scatter of the next, the first and the last beyond it).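

On the saturated chain carbon bound to an aromatic carbon and a saturated chain carbon, the aryl group now gives its first step beyond the scatter: a 2.1-fold higher number from compound 1 to compound 3 (0.31 log units; beyond the scatter) is what 4-chlorophenyl brings against 3-fluorophenyl, and the step is modest. Against 2-chlorophenyl, which has the same atoms, the reading is a 1.9-fold higher number from compound 2 to compound 3 (0.28 log units; within the scatter), so compound 3 cannot be separated from compound 2 in this assay on these numbers. The place is therefore not wholly flat on this read-out, yet only compound 1 and compound 3 stand apart, while compound 2 lies within the scatter of both. No accompanying measurement explains these steps.

As far as these compounds go, whether 4-fluorophenyl, 3-chlorophenyl or unsubstituted phenyl on the same carbon would fall with compound 1 or with compound 3 remains open, so the three values do not separate the kind of halogen from its place on the ring. Also open, from the compounds shown here alone, is how a pyridine ring, or a 1-(4-chlorophenyl)propyl group with its longer chain, would read at this position.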